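Carboxy for hydroxy on the core of compound 1

The source may hold more compounds than are shown below. What is called first, only, known or untested is meant among the compounds shown, and "the series" means these compounds.

Measured so far in a functional assay on Hep 3B2 cells (Homo sapiens) for antiproliferative activity, read by MTT assay, with a stated time of 24 h; a lower number here means a stronger inhibitor, a higher number a weaker inhibitor:
compound 1 `CCc1ccc2nc(C(=O)Nc3c(F)cc(-c4cccc(F)c4)cc3F)c(C)c(O)c2c1`: 15800 nM
compound 2 `Cc1c(C(=O)Nc2c(F)cc(-c3cccc(F)c3)cc2F)nc2ccc(F)cc2c1O`: > 100000 nM, a limit of this assay rather than a number
compound 3 `Cc1c(C(=O)Nc2c(F)cc(-c3cccc(F)c3)cc2F)nc2ccc(OC(F)(F)F)cc2c1O`: 85500 nM

Compound 1 holds the lowest of the two numbers shown; compound 3 is the nearest, and that gap is a 5.4-fold higher number from compound 1 to compound 3 (0.73 log units; beyond the scatter). Compound 2 reaches only the limit (the limit of > 100000 nM in this assay, at which 1 of the 3 values shown sits). Both measured steps leave the core untouched and vary the group on the other aromatic carbon: an at least 6.3-fold higher number from compound 1 to compound 2 (0.80 log units; beyond the scatter) and an at least 1.1-fold lower number from compound 2 to compound 3 (0.06 log units; that floor lies within the scatter). Every departure from compound 1 recorded so far has given a weaker inhibitor.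

Compound 4 `CCc1ccc2nc(C(=O)Nc3c(F)cc(-c4cccc(F)c4)cc3F)c(C)c(C(=O)O)c2c1` differs from compound 1 at the core itself: carboxy in place of hydroxy on an aromatic carbon. Going by the values given here, no measured step touches this place, so none of them bears on the change directly, and the expectation rests on the general picture that the series has so far lost potency on every change away from compound 1. For compound 4 the expected step is a 2.5-fold higher number from compound 1 to compound 4 (0.40 log units; beyond the scatter), a modest move towards weaker inhibition, with wide uncertainty and a real chance of a limit. The estimate for compound 4 in this assay is 40000 nM, expected to fall between 10000 nM and 150000 nM.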

Compound 4, half-maximal inhibitory concentration: 16900 nM
For compound 4 the middle estimate is 2.4-fold (0.37 log units) above the measured one; measured number inside the range.
By their numbers in this assay, from the lowest: compounds 1 and 4 (each within the scatter of the next); then compound 3. At a limit, above all of these: compound 2.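

In this assay, going by these compounds alone, the carboxy in place of hydroxy on an aromatic carbon gives a 1.1-fold higher number from compound 1 to compound 4 (0.03 log units; within the scatter) and is the first recorded departure from compound 1 that does not yield a weaker inhibitor. This place on the core, opposite the ring nitrogen and ortho to a methyl group, therefore accepts a group of three heavy atoms in place of one without a change beyond the scatter, whereas the replacements of ethyl on the other aromatic carbon in compound 2 and compound 3 both moved beyond it. No measurement at hand bears on the reason for this result.

On these data alone, whether this tolerance is specific to carboxy or extends to other groups at this place remains open, and a methyl ester, a primary amide or an amine there would test that. Also open, as far as these compounds go, is whether the same replacement reads alike when the ethyl group gives way to fluoro, to trifluoromethoxy or to a longer chain on the other aromatic carbon.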